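Constrained adenosine analogs: hydroxymethyl versus methylcarbamoyl

This account rests on a few compounds, and the source may have more. Where it says the series, first, only, none or still open, it means among the compounds named here.

Measured compounds:
- compound 1, `CNC(=O)[C@@]12CN[C@@H]([C@H](n3cnc4c(N)ncnc43)O1)[C@@H]2O` — in a functional assay for antagonist activity at adenosine receptor A1 (Homo sapiens) (on this read-out lower numbers stand for stronger inhibition and higher numbers for weaker inhibition), compound 1 gives "not determined" (no result reported).
- compound 2, `OC[C@@]12CN[C@@H]([C@H](n3cnc4c(NCc5cccc(I)c5)ncnc43)O1)[C@@H]2O` — in this assay compound 2 gives > 3000 nM.

Compound 1 carries the methylcarbamoyl group but lacks the iodobenzyl substituent, and no result has been reported for it. Compound 2 stands at the limit of this assay, so its value is a limit and not a number (the limit of > 3000 nM in this assay, at which 1 of the 2 values shown sits). Only one numeric-style entry exists for compound 2, and it is this limit; the remaining entry is without a single number. Going by the values given here, no step between two measured compounds is available, so the change that follows must be judged without a measured precedent.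

Compound 3, `CNC(=O)[C@@]12CN[C@@H]([C@H](n3cnc4c(NCc5cccc(I)c5)ncnc43)O1)[C@@H]2O`, differs from compound 2 in one place: methylcarbamoyl in place of hydroxymethyl on a saturated ring carbon. Among the compounds with values here, no measured pair shows what such a swap does here, so the expectation rests on the structural change alone. A step toward stronger inhibition is expected, estimated as an at least 2.0-fold lower number from compound 2 to compound 3 (0.30 log units; that floor lies within the scatter), though the chance that compound 3 again sits only at a limit remains considerable. Compound 3 is therefore expected to give about 1500 nM, within a range from 300 nM to 6000 nM.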

Compound 3, half-maximal inhibitory concentration: > 3000 nM
Compound 3: no number, only a limit; the forecaster's own chance of this, stated with the estimate: 45%; middle value at least 2.0-fold (0.30 log units) away from the limit.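

In this assay compound 3 gives > 3000 nM, which is a limit and not a number. Compound 2 gives > 3000 nM, also a limit. No step can therefore be read between compound 2 and compound 3: the limit of > 3000 nM in this assay, at which 2 of the 3 values shown sit.

The compounds shown leave open how strongly either compound inhibits, and whether methylcarbamoyl in place of hydroxymethyl changes inhibition at all.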